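Sulfanylamide series: replacing the amino ester arm on sulfur

This account rests on a few compounds, and the source may have more. Where it says the series, first, only, none or still open, it means among the compounds named here.

Compound 1 `N[C@@H](CSNC(=O)[C@@H](CCC(F)(F)F)N(Cc1ccc(-c2ncon2)cc1F)S(=O)(=O)c1ccc(Cl)cc1)C(=O)O` gives 418 h in a physicochemical assay for pharmacokinetics, at pH 4, tested at 100 ug/mL; on this read-out higher numbers stand for a longer-lived compound and lower numbers for a shorter-lived compound. Compound 2 `COC(=O)[C@@H](N)CSNC(=O)[C@@H](CCC(F)(F)F)N(Cc1ccc(-c2ncon2)cc1F)S(=O)(=O)c1ccc(Cl)cc1` gives 185 h in this assay, the lowest of the two numbers in hand; the step of a 2.3-fold lower number from compound 1 to compound 2 (0.35 log units; beyond the scatter). Compound 3 `O=C(NSc1ccccc1)[C@@H](CCC(F)(F)F)N(Cc1ccc(-c2ncon2)cc1F)S(=O)(=O)c1ccc(Cl)cc1` gives > 500 h in this assay, which is a limit of the assay rather than a number (the limit of > 500 h in this assay, at which 1 of the 3 values shown sits). The measured step that bears on the present question is an at least 2.7-fold higher number from compound 2 to compound 3 (0.43 log units; beyond the scatter); alongside it stands an at least 1.1-fold higher number from compound 1 to compound 3 (0.07 log units; that floor lies within the scatter).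

Compound 4 `N#CCCSNC(=O)[C@@H](CCC(F)(F)F)N(Cc1ccc(-c2ncon2)cc1F)S(=O)(=O)c1ccc(Cl)cc1` has not yet been measured. Its difference from compound 2: cyanomethyl in place of amino(methoxycarbonyl)methyl on a saturated chain carbon bound to a sulfur. As in the step to compound 3, the amino(methoxycarbonyl)methyl arm on the sulfur-bound chain is taken away, so an increase of at least comparable size is expected, with a fair chance that the read-out again stops at the limit. The estimate for compound 4 is 400 h, between 150 h and 500 h, which corresponds to an expected step of a 2.2-fold higher number from compound 2 to compound 4 (0.33 log units; beyond the scatter).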

Compound 4, half-life: > 500 h
Compound 4 gave a limit, no number; the forecaster's own chance of this, stated with the estimate: 35%; at least 1.2-fold (0.09 log units) between middle value and limit.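

Replacing the amino(methoxycarbonyl)methyl arm with cyanomethyl, which has no ring and no hydrogen-bond donor, gives an at least 2.7-fold higher number from compound 2 to compound 4 (0.43 log units; beyond the scatter) in this assay, so a phenyl on the sulfur is not required for this rise. Against the free acid the step is an at least 1.1-fold higher number from compound 1 to compound 4 (0.07 log units; that floor lies within the scatter), a floor within the scatter, so no order can be claimed for that pair. Compound 4 gives a limit rather than a number, and the step from compound 3 to compound 4 cannot be read: the limit of > 500 h in this assay, at which 2 of the 4 values shown sit.

On these data alone, it remains open whether the amine or the methyl ester of the arm goes with the lower number of compound 2, which a 2-aminoethyl arm or a plain ethyl arm on the sulfur would help to separate. As far as these compounds go, with the read-out stopped at the limit, the ranking of the phenyl and 2-cyanoethyl arms also stays open, and a longer chain ending in a nitrile would not settle it unless it gave a number.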